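This account rests on a few compounds, and the source may have more. Where it says the series, first, only, none or still open, it means among the compounds named here.

Of the compounds shown here, three built on one shared core have been tested in a functional assay on HCT-116 cells (Homo sapiens) for antiproliferative activity, read by CCK-8 assay, with a stated time of 72 h, tested at 8 uM; a lower number here means a weaker effect, a higher number a stronger effect of the compound at the concentration tested. Compound 1 `CCC(C)n1cnc2c(NCc3ccc(C(=O)Nc4ccccc4N)cc3)nc(Cl)nc21` gives 75.1% in this assay. Compound 2 `Cc1ccc(Nc2nc(Cl)nc3c2ncn3Cc2ccc(C(=O)Nc3ccccc3N)cc2)cc1` gives 81.5% in this assay, and compound 3 `Nc1ccccc1NC(=O)c1ccc(Cn2cnc3c(Nc4ccccc4)nc(Cl)nc32)cc1` gives 83.5% in this assay. On the numbers shown, compound 3 stands at the top of the three, but its gaps to compound 2 and to compound 1 are both within the usual scatter, so the three cannot be told apart. Going by the values given here, the only single-point step among them, a number 2 percentage points higher from compound 2 to compound 3 (within the scatter), is likewise within the scatter.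

Compound 4 `Nc1ccccc1NC(=O)c1ccc(Cn2cnc3c(NCc4ccccc4)nc(Cl)nc32)cc1` has not yet been measured. It differs from compound 3 by benzyl in place of phenyl on a nitrogen on an aromatic ring. Among the compounds with values here, no measured step concerns this nitrogen: the step from compound 2 to compound 3 alters a group on an aromatic carbon of the phenyl that now leaves, and compound 1, the only compound whose amino nitrogen carries a benzyl rather than a phenyl, also differs at another place, so its number can only be set beside that of compound 3, where the two lie within the scatter of each other. On that basis the expected step of a number 5.5 percentage points lower from compound 3 to compound 4 (within the scatter) is small, with no direction beyond the scatter. Compound 4 is therefore estimated at 78% in this assay, with a range from 65% to 88%.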

Compound 4, a percentage reported as inhibition, at one concentration (the size of the read-out at that concentration, not a potency): 78.4%
Beside the measured number, compound 4's estimate is 0.4 percentage points below it; low and high end bracket the measured number.
By their numbers in this assay, from the lowest: compounds 1, 4, 2 and 3 (each within the scatter of the next).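

In this assay, this nitrogen now has a direct test: the anilino group becomes benzylamino, so benzyl with its 7 heavy atoms replaces phenyl with its 6, and the ring no longer sits directly on the nitrogen. This gives a number 5.1 percentage points lower from compound 3 to compound 4 (within the scatter) and, with benzyl in place of 4-methylphenyl, a number 3.1 percentage points lower from compound 2 to compound 4 (within the scatter); both steps are within the scatter, so in this read-out at this single concentration, benzyl cannot be told apart from phenyl or 4-methylphenyl at this position. Nothing available explains why these groups give such similar numbers.

Still open, as far as these compounds go, is whether a group of another kind on this nitrogen, such as a longer chain like 2-phenylethyl, a ring-free chain like butyl, or a chain ending in an amine, would move the number beyond the scatter. Also open, from the compounds shown here alone, is whether compound 2, compound 3 and compound 4 would separate at lower concentrations, since a percentage taken at one concentration is a size of effect and not a potency.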